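Removing One Methoxy Group: Cytotoxicity in Bovine Kidney Cells

This account rests on a few compounds, and the source may have more. Where it says the series, first, only, none or still open, it means among the compounds named here.

Compound 1, `COc1ccc(-c2nc3cc(C(F)(F)F)ccc3[nH]2)c(OC)c1OC`: in an ADME assay on MDBK cells (Bos taurus) for cytotoxicity, read by MTT assay, with a stated time of 96 h (a lower number here means that less compound is tolerated, a higher number that more compound is tolerated), compound 1 gives > 100000 nM.
Compound 2, `Oc1ccc(-c2nc3cc(C(F)(F)F)ccc3[nH]2)cc1`: in this assay compound 2 gives 51000 nM.

The value of compound 1 is a limit of this assay rather than a number, and this is where compound 1 stands: at the limit of > 100000 nM in this assay, at which 1 of the 2 values shown sits. Among the compounds with values here, compound 2, which carries a hydroxy in place of the three methoxy groups, gives a number below that limit, but with no step set out between the two compounds their values can only be reported side by side.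

The step to be followed leads from compound 1 to compound 3, `COc1ccc(-c2nc3cc(C(F)(F)F)ccc3[nH]2)c(OC)c1`. Between them the difference is hydrogen in place of methoxy on an aromatic carbon. Within the data shown here, no measured step offers a direct comparison for this change. Given that compound 1 reaches the limit at the limit of > 100000 nM in this assay, at which 1 of the 2 values shown sits, the expectation is that compound 3 will also be well tolerated, with a step from compound 1 to compound 3 of a number no higher from compound 1 to compound 3 (the limit leaves the size open), that is, none beyond the scatter. Compound 3 is therefore estimated at 100000 nM, within the range 40000 nM to 250000 nM, with a fair chance that this assay again reports only a limit.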

Compound 3, half-maximal cytotoxic concentration: > 100000 nM
Compound 3: no number, only a limit; the forecaster's own chance of this, stated with the estimate: 55%; the middle value lies on the limit itself.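

In this assay compound 3 gives > 100000 nM, which is a limit of the assay and not a number. Within the data shown here, compound 1 also stands at a limit, and no step between compound 1 and compound 3 can be read. The compounds shown leave open whether exchanging this methoxy for hydrogen changes tolerance at all.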